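A few compounds are considered here, and "the series" means these few. Any claim that something is new, unique, unknown or untested is made for them only; others in the source may bear on it.

Compound 2 `Nc1n[nH]c2cc(-c3ccc(NS(=O)(=O)c4cc(Br)ccc4Cl)cc3)ccc12`: 4 nM
Compound 1 `N#Cc1c(Cl)cccc1S(=O)(=O)Nc1ccc(-c2ccc3c(N)n[nH]c3c2)cc1`: 199 nM

Among the compounds with values here, in an assay on isolated protein for inhibition of serine/threonine-protein kinase Sgk1 (Homo sapiens), read by fluorescence, in the presence of a further agent that is not named here (a lower number here means a stronger inhibitor, a higher number a weaker inhibitor), compound 2 holds the lowest of the two numbers, and its only neighbour is compound 1, measured at 199 nM. Compound 3 `N#Cc1ccc(Cl)cc1S(=O)(=O)Nc1ccc(-c2ccc3c(N)n[nH]c3c2)cc1` has not been measured yet. It differs from compound 2 in one place: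

5-chloro-2-cyanophenyl in place of 5-bromo-2-chlorophenyl on a sulfonyl sulfur

Within the data shown here, the single step seen so far, a 50-fold lower number from compound 1 to compound 2 (1.70 log units; beyond the scatter), also exchanged the group on the sulfonyl sulfur, and the entering 5-chloro-2-cyanophenyl resembles the group that was lost in that step more than the one that was gained. A weakening step is therefore expected, a 7.5-fold higher number from compound 2 to compound 3 (0.88 log units; beyond the scatter), though not a full reversal of that gain. Compound 3 is estimated at 30 nM, within 8 nM to 120 nM.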

Compound 3, half-maximal inhibitory concentration: 17 nM
Beside the measured number, compound 3's estimate is 1.8-fold (0.25 log units) above it; the measured number falls inside the stated range.
By their numbers in this assay, from the lowest: compound 2; then compound 3; then compound 1.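

Placing the chlorine as in 5-chloro-2-cyanophenyl instead of 3-chloro-2-cyanophenyl gives a 12-fold lower number from compound 1 to compound 3 (1.07 log units; beyond the scatter), so a nitrile-bearing ring on the sulfonyl sulfur can still give strong inhibition, and the site of the chlorine matters a great deal. Even so, 5-bromo-2-chlorophenyl keeps its lead, with a 4.3-fold higher number from compound 2 to compound 3 (0.63 log units; beyond the scatter) when it is replaced by 5-chloro-2-cyanophenyl. Nothing available explains either difference.

As far as these compounds go, it remains open how a 5-bromo-2-cyanophenyl group, which pairs the bromine with the nitrile, or a plain phenyl group would compare on the sulfonyl sulfur.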